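The compounds below may be only part of what the source reports. "The series", "measured", "known", "first", "only" and "open" are said of these compounds alone.

Among the compounds with values here, in a physicochemical assay for solubility, read by nephelometry, measured as kinetic solubility, at pH 2 (a higher number here means a more soluble compound, a lower number a less soluble compound), compound 2 `Cc1cc(NC(=O)Nc2ccc(F)c(C(F)(F)F)c2)on1` gives 12.5 ug/mL, the higher of the two numbers so far, while compound 1 `O=C(Nc1ccc(F)c(C(F)(F)F)c1)Nc1cnccn1` gives 1.6 ug/mL. Compound 3 `O=C(Nc1ccncc1)Nc1ccc(F)c(C(F)(F)F)c1` changes the same place: pyridin-4-yl in place of 3-methyl-1,2-oxazol-5-yl on an amide-type nitrogen, so pyridin-4-yl stands in place of 3-methyl-1,2-oxazol-5-yl on an amide-type nitrogen. Within the data shown here, only one measured step bears on this place, a 7.8-fold higher number from compound 1 to compound 2 (0.89 log units; beyond the scatter), and it is modest but beyond the scatter. Among the measured compounds shown here, no measured compound yet carries pyridin-4-yl, so the direction is uncertain, but a modest rise is expected. The estimate for this move is a 2.4-fold higher number from compound 2 to compound 3 (0.38 log units; beyond the scatter). Compound 3 is expected at 30 ug/mL, with an estimated range of 6 ug/mL to 120 ug/mL.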

Compound 3, solubility: 6.3 ug/mL
For compound 3 the middle estimate is 4.8-fold (0.68 log units) above the measured one; low and high end bracket the measured number.
By their numbers in this assay, from the lowest: compound 1; then compounds 3 and 2 (each within the scatter of the next).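

In this assay, the change to pyridin-4-yl gives a 2.0-fold lower number from compound 2 to compound 3 (0.30 log units; within the scatter) and so does not separate it from 3-methyl-1,2-oxazol-5-yl at this amide-type nitrogen. Set against pyrazin-2-yl, the same group gives a 3.9-fold higher number from compound 1 to compound 3 (0.60 log units; beyond the scatter), which leaves compound 1 as the lowest of the three, now apart from both other compounds. Nothing shown here accounts for these differences. On these data alone, it remains open whether a pyridine joined through another ring atom would read like compound 3. Also open, as far as these compounds go, is how an aliphatic amine or a carboxylic acid on the ring at this nitrogen would compare.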